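The source may hold more compounds than are shown below. What is called first, only, known or untested is meant among the compounds shown, and "the series" means these compounds.

Of the compounds shown here, three of one shared core have been measured in a functional assay on MCF7 cells (Homo sapiens) for cytotoxicity, read by resazurin assay, with a stated time of 3 days; on this read-out higher numbers stand for weaker inhibition and lower numbers for stronger inhibition. Compound 1 `CC(C)(CNC(=O)c1ccc2ccccc2c1O)CC1=C(O)C(=O)c2ccccc2C1=O` gives 79500 nM. Compound 2 `COc1c(C(=O)NCC(C)(C)CC2=C(O)C(=O)c3ccccc3C2=O)ccc2ccccc12`, carrying a methyl in place of hydrogen on an oxygen on an aromatic ring, gives 39800 nM. Compound 3 `COc1cc(C(=O)NCC(C)(C)CC2=C(O)C(=O)c3ccccc3C2=O)c(O)c2ccccc12`, carrying a methoxy in place of hydrogen on an aromatic carbon, gives 35600 nM. Compound 3 shows the lowest number of the three, yet its gap to compound 2 is within the scatter, so no order between those two can be read; only compound 1 stands apart from it.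

Compound 4 `COc1cc(C(=O)NCC(C)(C)CC2=C(O)C(=O)c3ccccc3C2=O)c(OC)c2ccccc12` has not yet been measured. It differs from compound 3 by methyl in place of hydrogen on an oxygen on an aromatic ring. Going by the values given here, the step that bears on this change is the one between compound 1 and compound 2, which is the same replacement, a methyl in place of hydrogen on an oxygen on an aromatic ring: a 2.0-fold lower number from compound 1 to compound 2 (0.30 log units; within the scatter). The other measured step, a 2.2-fold lower number from compound 1 to compound 3 (0.35 log units; beyond the scatter), concerns a different change and is only a weak guide. On this basis a small step toward a lower number, if any, is expected, and it is estimated as a 1.4-fold lower number from compound 3 to compound 4 (0.14 log units; within the scatter). Compound 4 is therefore expected to give about 26000 nM in this assay, with a range from 11000 nM to 62000 nM.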

Compound 4, half-maximal inhibitory concentration: "not active" (no number reported)
For compound 4 the study gives words and no number, so the estimate cannot be set against anything.
By their numbers in this assay, from the lowest: compounds 3, 2 and 1 (each within the scatter of the next, the first and the last beyond it).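

Going by these compounds alone, compound 4 is described in this assay only in words, as "not active", so no step from compound 3 to compound 4 can be read. Nothing available here bears on the reason for this result. Compound 3 carries hydroxy where compound 4 carries methoxy. The compounds shown leave the size of the difference between these two open.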